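Side chain swap on the shared core: working notes

The source may report more compounds than this note shows. Statements on the series, on what has been measured and on what is new or still open speak of the compounds shown alone.

Four compounds are under review in a functional assay on A549 cells (Homo sapiens) for cytotoxicity, read by MTT assay, with a stated time of 48 h; a lower number here means a stronger inhibitor, a higher number a weaker inhibitor. For compound 1 `CC(C)NCCOc1c(O)cc(O)c2c(=O)cc(-c3ccccc3)oc12` the entry reads "not determined" (no result reported). For compound 3 `COc1c(O)cc(O)c2c(=O)cc(-c3ccc(F)cc3Br)oc12` the entry reads "not determined" (no result reported). Among the compounds with values here, compound 2 `COc1c(OCCCCN2CCCCC2)cc(O)c2c(=O)cc(-c3ccccc3)oc12` gives 1150 nM, the only number available, so its standing relative to the other compounds cannot be judged.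

Compound 4 `CCN(CC)CCCOc1cc(O)c2c(=O)cc(-c3ccccc3)oc2c1OC` has yet to be measured. It differs from compound 2 as follows: diethylamino in place of (piperidin-1-yl)methyl on a saturated chain carbon, three bonds along the chain from an oxygen on an aromatic ring. Cut one bond further out, the same difference reads 4-(piperidin-1-yl)butyl to 3-(diethylamino)propyl. The rest of the structure is unchanged.

Within the data shown here, no measured pair tests this kind of change, and no trend can be drawn from a single number. The expectation therefore rests on compound 2 at 1150 nM as the sole anchor, and the uncertainty is wide. The expected step, a 1.6-fold higher number from compound 2 to compound 4 (0.19 log units; within the scatter), is small and towards weaker inhibition, with no firm shift beyond the scatter anticipated. For compound 4 the estimated value in this assay is 1800 nM, with an expected range of 600 nM to 5500 nM.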

Compound 4, half-maximal inhibitory concentration: 1830 nM
For compound 4 the middle estimate is 1.0-fold (0.01 log units) below the measured one, and the stated range covers the measured number.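

In this assay, within the data shown here, the change at this position, diethylamino in place of (piperidin-1-yl)methyl on a saturated chain carbon, three bonds along the chain from an oxygen on an aromatic ring, gives a 1.6-fold higher number from compound 2 to compound 4 (0.20 log units; within the scatter) and is the first step that can be read. Compound 2 and compound 4 therefore cannot be told apart in this read-out, so the side chain at this position can go from 4-(piperidin-1-yl)butyl to 3-(diethylamino)propyl, losing the six-membered ring, without a shift beyond the scatter. No measured evidence bears on this result, and the step remains an observation without an explanation.

This single pair changes the ring and the chain together, so a 3-(piperidin-1-yl)propyl or a 4-(diethylamino)butyl side chain would be needed to separate the two changes. From the compounds shown here alone, whether the same tolerance extends to other chain ends, such as a morpholine, a primary amine or a carboxylic acid, remains open, and compound 1 and compound 3 carry no number that could widen the comparison.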